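This account rests on a few compounds, and the source may have more. Where it says the series, first, only, none or still open, it means among the compounds named here.

Working notes on the series. Compound 1 `CS(=O)(=O)c1ccc(-c2cnc3[nH]cc(-c4nnc(-c5ccncc5)o4)c(=O)c3c2)cc1` and compound 2 `CS(=O)(=O)c1ccc(-c2cnc3[nH]cc(-c4nnc(-c5ccccc5)o4)c(=O)c3c2)cc1` share one core and differ only in the aryl group on the oxadiazole. In a functional assay on KB cells (Homo sapiens) for inhibition, read by MTT assay, with a stated time of 24 h, tested at 5 uM (on this read-out higher numbers stand for more inhibition of growth at the one concentration tested and lower numbers for less inhibition of growth), compound 1 gives 2.16%, and in this assay compound 2 gives 4.38%; the two numbers sit within the scatter of each other, as the step of a number 2.2 percentage points higher from compound 1 to compound 2 (within the scatter) shows. Both compounds therefore read as near-inactive at the single concentration tested.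

Compound 3 `Cc1ccc(-c2nnc(-c3c[nH]c4ncc(-c5ccc(S(C)(=O)=O)cc5)cc4c3=O)o2)cc1` is the next member. Its difference from compound 2 is methyl in place of hydrogen on an aromatic carbon. Among the compounds with values here, no measured step probes this change; the only step in hand, a number 2.2 percentage points higher from compound 1 to compound 2 (within the scatter), concerns a swap of the whole aryl group and lay within the scatter. On that footing no step beyond the scatter is expected in this assay from compound 2 to compound 3, i.e. an expected shift of a number 0.1 percentage points higher from compound 2 to compound 3 (within the scatter). Compound 3 is accordingly estimated at 4.5%, with a range from -5% to 15%.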

Compound 3, percent growth inhibition at one concentration: 0.43%
Beside the measured number, compound 3's estimate is 4.1 percentage points above it; low and high end bracket the measured number.
By their numbers in this assay, from the lowest: compounds 3, 1 and 2 (each within the scatter of the next).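

In this assay, methyl in place of hydrogen on an aromatic carbon, para to a large group, gives a number 4 percentage points lower from compound 2 to compound 3 (within the scatter), so this first probe of the position on the phenyl group produces no step beyond the scatter. The change from pyridin-4-yl to 4-methylphenyl gives a number 1.7 percentage points lower from compound 1 to compound 3 (within the scatter), which extends the flat picture to a third aryl group at this place, with all three compounds near-inactive at the single concentration tested. Nothing at hand bears on the reason for this flat read-out.

On these data alone, whether an amine, a carboxylic acid or a longer chain at this position would give a step beyond the scatter remains open. Also open, as far as these compounds go, is whether these three compounds would separate at another concentration.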